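A few compounds are considered here, and "the series" means these few. Any claim that something is new, unique, unknown or untested is made for them only; others in the source may bear on it.

Measured so far in an assay on isolated protein for agonist activity at Bile acid receptor (Homo sapiens), read by FRET; on this read-out higher numbers stand for an effect only at larger amounts of compound and lower numbers for an effect already at smaller amounts:
compound 1 `CN(Cc1cccc(C(=O)O)c1)c1ccc(OCc2c(-c3c(Cl)cccc3Cl)noc2C2CC2)nc1C(F)(F)F` gives 3 nM
compound 2 `CN(Cc1ccc(C(=O)O)cc1)c1ccc(OCc2c(-c3c(Cl)cccc3Cl)noc2C2CC2)nc1C(F)(F)F` gives 12 nM
compound 3 `CC(Oc1cccc(C(=O)O)c1)c1ccc(OCc2c(-c3c(Cl)cccc3Cl)noc2C2CC2)nc1C(F)(F)F` gives 155 nM

Compound 3 stands at the highest number of the three in this assay: against compound 2 the gap is a 13-fold higher number from compound 2 to compound 3 (1.11 log units; beyond the scatter) and against compound 1 it is a 52-fold higher number from compound 1 to compound 3 (1.71 log units; beyond the scatter), both beyond the scatter. Compound 4 `CC(Oc1ccc(C(=O)O)cc1)c1ccc(OCc2c(-c3c(Cl)cccc3Cl)noc2C2CC2)nc1C(F)(F)F` is not yet measured. It differs from compound 3 by 4-carboxyphenyl in place of 3-carboxyphenyl on an oxygen on a saturated carbon. Within the data shown here, one measured step bears on this: the same swap of the carboxyphenyl group, there on a saturated chain carbon bound to a nitrogen on an aromatic ring, gave a 4.0-fold higher number from compound 1 to compound 2 (0.60 log units; beyond the scatter). Among the measured compounds shown here, whether the swap behaves alike on the oxygen-linked arm is untested, as no pair with that linkage has both carboxyphenyl forms measured. The working expectation is a modest step in the same direction, a 3.2-fold higher number from compound 3 to compound 4 (0.51 log units; beyond the scatter), with wide uncertainty since a single comparison supports it. Compound 4 is therefore estimated at 500 nM, within a range of 150 nM to 1700 nM.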

Compound 4, half-maximal effective concentration: 352 nM
Estimate against measurement, compound 4: 1.4-fold (0.15 log units) above, and the stated range covers the measured number.
By their numbers in this assay, from the lowest: compound 1; then compound 2; then compound 3; then compound 4.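

In this assay, the swap to 4-carboxyphenyl on an oxygen on a saturated carbon gives a 2.3-fold higher number from compound 3 to compound 4 (0.36 log units; beyond the scatter) in the same direction as the nitrogen-linked pair, where the swap gave a 4.0-fold higher number from compound 1 to compound 2 (0.60 log units; beyond the scatter) on the other linkage. Within each linkage of these four compounds, the 3-carboxyphenyl form therefore has the lower number, and no compound shown goes against this. The oxygen-linked arm also keeps its disadvantage in the 4-carboxyphenyl form, with a 29-fold higher number from compound 2 to compound 4 (1.47 log units; beyond the scatter) against its direct nitrogen-linked counterpart and a 120-fold higher number from compound 1 to compound 4 (2.07 log units; beyond the scatter) against the 3-carboxybenzyl compound.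

On these data alone, whether this order would hold with a tetrazole in place of the carboxylic acid, or with an amide in the linking chain, remains open. No available evidence accounts for the effect of the swap or the linkage.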